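The compounds below may be only part of what the source reports. "The series", "measured", "known", "first", "only" and "open" are said of these compounds alone.

Series notes. Going by the values given here, the shared core is held constant across the three measured members, compound 1 `C=C(C)[C@@H]1CC=C(Cn2cc(COc3cccc(C4NC(=O)NC(C)=C4C(=O)OCC)c3)nn2)CC1`, compound 2 `C=C(C)[C@@H]1CC=C(Cn2cc(COc3cc(C4NC(=O)NC(C)=C4C(=O)OCC)ccc3OC)nn2)CC1` and compound 3 `C=C(C)[C@@H]1CC=C(Cn2cc(COc3ccc(C4NC(=O)NC(C)=C4C(C)=O)cc3)nn2)CC1`. In a functional assay on NCI-H460 cells (Homo sapiens) for inhibition, read by sulforhodamine B assay, with a stated time of 48 h (a higher number here means a weaker inhibitor of growth, a lower number a stronger inhibitor of growth), compound 1 reaches only the limit > 100000 nM. In this assay compound 2 likewise reaches only the limit > 100000 nM. The step from compound 1 to compound 2, a step that the two limits leave unreadable from compound 1 to compound 2, is therefore unreadable, and compound 2 stands at the limit with no number of its own; the relevant point is the limit of > 100000 nM in this assay, at which 2 of the 3 values shown sit. Among the compounds with values here, compound 3 gives 78200 nM in this assay; it differs from compound 1 in two places, so no single step connects them.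

Compound 4 `C=C(C)[C@@H]1CC=C(Cn2cc(COc3cc(C4NC(=O)NC(C)=C4C(C)=O)ccc3OC)nn2)CC1` is not yet measured. It differs from compound 2 by methyl in place of ethoxy on a carbonyl carbon. Within the data shown here, no measured step isolates this change: compound 3 carries the acetyl but differs from compound 2 in a second place as well. Among the measured compounds shown here, the only measured step, from compound 1 to compound 2, concerns a different change and is unreadable. The expectation for this assay therefore rests on the limits alone: no step beyond the scatter in either direction is expected, and compound 4 is most likely to sit at the limit again. Compound 4 is estimated at 120000 nM, range 40000 nM to 400000 nM. The expected size of the change is a step that the limit leaves unreadable from compound 2 to compound 4.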

Compound 4, concentration for total growth inhibition: > 100000 nM
Compound 4: only a limit was reported; the forecaster's own chance of this, stated with the estimate: 60%; the middle value does not contradict the limit.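

Compound 2 and compound 4 both give only a limit in this assay, so no step can be read between them: the limit of > 100000 nM in this assay, at which 3 of the 4 values shown sit.

The compounds shown leave open what methyl in place of ethoxy on a carbonyl carbon does on its own in this assay, as no pair differing only in that change has a number on both sides.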